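The source may report more compounds than this note shows. Statements on the series, on what has been measured and on what is new or still open speak of the compounds shown alone.

Measured compounds in the series:

compound 1 `CN1CCC(NC(=O)c2cc(-c3ccc(NS(=O)(=O)c4cccc(Cl)c4Cl)cc3)nc3[nH]ncc23)C1` — 21 nM
compound 2 `NC(=O)c1cc(-c2ccc(NS(=O)(=O)c3cccc(Cl)c3Cl)cc2)nc2[nH]ncc12` — 236 nM
compound 3 `CN(C)CCCNC(=O)c1cc(-c2ccc(NS(=O)(=O)c3cccc(Cl)c3Cl)cc2)nc2[nH]ncc12` — 633 nM

In an assay for inhibition of serine/threonine-protein kinase Sgk1 (Homo sapiens), with stated times of 30 min and 60 min, in the presence of a further agent that is not named here (a lower number here means a stronger inhibitor, a higher number a weaker inhibitor), compound 3 stands at the highest of the three numbers. Its nearest neighbour is compound 2, reached by a 2.7-fold higher number from compound 2 to compound 3 (0.43 log units; beyond the scatter), and its furthest is compound 1, reached by a 30-fold higher number from compound 1 to compound 3 (1.48 log units; beyond the scatter). Compound 4 `CN1CCC(CNC(=O)c2cc(-c3ccc(NS(=O)(=O)c4cccc(Cl)c4Cl)cc3)nc3[nH]ncc23)C1` is the next compound and has not yet been measured. It differs from compound 3 in one place: 1-methylpyrrolidin-3-yl in place of 2-(dimethylamino)ethyl on a saturated chain carbon bound to an amide-type nitrogen.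

For the measured compounds named here, of the measured steps, the one from compound 1 to compound 3 bears most directly on this change, since compound 1 carries the 1-methylpyrrolidin-3-yl group directly on the amide-type nitrogen, whereas compound 4 carries it on a saturated chain carbon bound to that nitrogen; a 30-fold higher number from compound 1 to compound 3 (1.48 log units; beyond the scatter) was large. The step from compound 2 to compound 3 shows that the 3-(dimethylamino)propyl chain itself gave a modest rise. Going by the values given here, no measured pair shows the effect of inserting the extra chain carbon, so the expectation is a large drop in number, somewhat short of a full return to compound 1. For compound 4 the expected step is an 11-fold lower number from compound 3 to compound 4 (1.02 log units; beyond the scatter), giving an estimated value of 60 nM, with a range from 20 nM to 200 nM.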

Compound 4, half-maximal inhibitory concentration: 45 nM
For compound 4 the middle estimate is 1.3-fold (0.12 log units) above the measured one; the range from low to high includes it.
By their numbers in this assay, from the lowest: compound 1; then compound 4; then compound 2; then compound 3.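

In this assay, 3-(dimethylamino)propyl replaced by (1-methylpyrrolidin-3-yl)methyl gives a 14-fold lower number from compound 3 to compound 4 (1.15 log units; beyond the scatter) with the amide-type nitrogen unchanged, so the ring-bearing group is much preferred over the open chain here. Set against the unsubstituted amide, (1-methylpyrrolidin-3-yl)methyl gives a 5.2-fold lower number from compound 2 to compound 4 (0.72 log units; beyond the scatter) while 3-(dimethylamino)propyl moves the number the other way, so substitution on this nitrogen can either help or hurt depending on the group. Placing the ring on a saturated chain carbon rather than directly on the nitrogen gives only a 2.1-fold higher number from compound 1 to compound 4 (0.33 log units; beyond the scatter) as a modest penalty, so the ring tolerates that shift fairly well.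

Open, as far as these compounds go, is whether a piperidine ring, a pyrrolidine with a free ring amine or a longer chain to the ring would hold this level in the same place. The compounds shown offer no measurement that explains these steps.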